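From methylamino to dimethylamino: one more methyl

The source may hold more compounds than are shown below. What is called first, only, known or untested is meant among the compounds shown, and "the series" means these compounds.

Compound 1 `CCCCCCCCCC(CCO)n1cnc2c(Cl)ncnc21` gives 1150 nM
Compound 2 `CCCCCCCCCC(CCO)n1cnc2c(NC)ncnc21` gives 4450 nM
Compound 3 `CCCCCCCCCC(CCO)n1cnc2c(N(C)C)ncnc21` is not yet measured

Among the compounds with values here, in a functional assay on SW480 cells (Homo sapiens) for antiproliferative activity, read by MTT assay, with a stated time of 48 h (a lower number here means a stronger inhibitor, a higher number a weaker inhibitor), compound 2 stands at 4450 nM and holds the higher, weaker number of the two measured so far. Compound 3 differs from it in one place, and that difference is methyl in place of hydrogen on a nitrogen on an aromatic ring with methyl in place of hydrogen on a nitrogen on an aromatic ring, so methylamino becomes dimethylamino.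

Within the data shown here, only one measured step bears on this: a 3.9-fold higher number from compound 1 to compound 2 (0.59 log units; beyond the scatter) with methylamino in place of chloro on an aromatic carbon. That step is modest and swaps one group for a different one, so it shows that this spot can shift the number. Among the measured compounds shown here, it does not show what an added methyl does, and no measured pair tests that change directly. The expected step is therefore small, with no clear direction and nothing beyond the usual scatter anticipated: a 1.1-fold lower number from compound 2 to compound 3 (0.05 log units; within the scatter) is the estimate. The estimate for compound 3 is 4000 nM in this assay with an expected range from 1700 nM to 9500 nM as its wide limits.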

Compound 3, half-maximal inhibitory concentration: 12200 nM
For compound 3 the middle estimate is 3.1-fold (0.48 log units) below the measured one; the whole stated range lies below it.
By their numbers in this assay, from the lowest: compound 1; then compound 2; then compound 3.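

In this assay, within the data shown here, adding a methyl to the nitrogen gives a 2.7-fold higher number from compound 2 to compound 3 (0.44 log units; beyond the scatter) so this is the first direct look at what that change does, and here the number rises rather than holding steady. Replacing chloro with dimethylamino gives an 11-fold higher number from compound 1 to compound 3 (1.03 log units; beyond the scatter) and this is a larger rise than either of the two smaller steps alone, so the group at this spot can move the number a long way. Across these three compounds the order runs from chloro through methylamino to dimethylamino, with every step beyond the usual scatter, but no measurement here explains why the number rises.

The plain amino group, with hydrogens in place of both methyls, would show whether the rise in the number also holds at the low end of this series, while ethylamino would show whether a longer chain on the nitrogen behaves as the added methyl does. As far as these compounds go, the effect of these changes alongside a shorter chain in place of the long one on the rest of the molecule also remains open.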